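From compound 3 to compound 4: methyl to ethyl

The compounds below may be only part of what the source reports. "The series", "measured", "known", "first", "only" and "open" are said of these compounds alone.

In an ADME assay (liver) for metabolic stability, with Liver microsome (Rattus norvegicus) as the target, read by LC-MS, using microsomes, with a stated time of 30 min, tested at 4 uM (on this read-out lower numbers stand for a less stable compound and higher numbers for a more stable compound), compound 3 `Cc1nc(N2CCN(C)CC2)c2nc(-c3ccccc3C)n(C3CCOCC3)c2n1` gives 39%, compound 2 `Cc1nc(N2CCN(C)CC2)c2nc(-c3ccccc3C(F)(F)F)n(C3CCOCC3)c2n1` gives 38% and compound 1 `Cc1nc(N2CCN(C)CC2)c2nc(-c3cccc(Cl)c3)n(C3CCOCC3)c2n1` gives 45%. All three values lie within the scatter of one another. Compound 4 `CCc1ccccc1-c1nc2c(N3CCN(C)CC3)nc(C)nc2n1C1CCOCC1` carries methyl in place of hydrogen on a saturated chain carbon bound to an aromatic carbon, which turns 2-methylphenyl into 2-ethylphenyl (methyl in place of hydrogen on a saturated chain carbon bound to an aromatic carbon). Among the measured compounds shown here, two measured steps bear on this: methyl in place of trifluoromethyl gave a number 1 percentage points higher from compound 2 to compound 3 (within the scatter), and 2-methylphenyl in place of 3-chlorophenyl gave a number 6 percentage points lower from compound 1 to compound 3 (within the scatter). Neither tests this exact change, but both are small, so no shift beyond the scatter is expected. The estimated step is a number 2 percentage points lower from compound 3 to compound 4 (within the scatter). For compound 4 the expected value is 37%, with an estimated range from 25% to 49%.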

Compound 4, percent of the compound remaining: 51%
Compound 4: middle estimate off by 14 percentage points, on the low side; measured number outside the range, above it.
By their numbers in this assay, from the lowest: compounds 2, 3, 1 and 4 (each within the scatter of the next, the first and the last beyond it).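

In this assay, among the compounds shown here, one added methyl on a saturated chain carbon bound to an aromatic carbon produces the first steps beyond the scatter at this position: a number 12 percentage points higher from compound 3 to compound 4 (beyond the scatter), and a number 13 percentage points higher from compound 2 to compound 4 (beyond the scatter). Against 3-chlorophenyl, 2-ethylphenyl gives a number 6 percentage points higher from compound 1 to compound 4 (within the scatter), so it does not separate from that group. No measured evidence bears on the reason for this step.

The compounds shown leave open whether a longer chain such as propyl, or a branched isopropyl, would raise the number again. They also leave open whether a methoxy group at this place would match ethyl.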